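Notes on the group at the aromatic nitrogen

The compounds below may be only part of what the source reports. "The series", "measured", "known", "first", "only" and "open" are said of these compounds alone.

Measured compounds:
compound 1 `CCCCn1ccc2cc(/C(C)=C/C(=O)Nc3ccccc3OCCCC(=O)O)ccc21`: 43 nM
compound 2 `CCCCCn1ccc2cc(/C(C)=C/C(=O)Nc3ccccc3OCCCC(=O)O)ccc21`: 23 nM
compound 3 `C/C(=C\C(=O)Nc1ccccc1OCCCC(=O)O)c1ccc2c(ccn2CC(C)C)c1`: 160 nM

In an assay on Prostate gland for inhibition of steroid 5-alpha-reductase (Rattus norvegicus) (on this read-out lower numbers stand for stronger inhibition and higher numbers for weaker inhibition), compound 3 stands at the highest of the three numbers. Compound 1 lies nearest and compound 2 furthest; both gaps run beyond the scatter, as the steps of a 3.7-fold higher number from compound 1 to compound 3 (0.57 log units; beyond the scatter) and a 7.0-fold higher number from compound 2 to compound 3 (0.84 log units; beyond the scatter) show. The step of a 1.9-fold lower number from compound 1 to compound 2 (0.27 log units; within the scatter) stays within the scatter, so lengthening the straight chain by one carbon tells little, while the isopropyl branch at the carbon bound to the aromatic nitrogen is what sets compound 3 apart.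

Compound 4 `C/C(=C\C(=O)Nc1ccccc1OCCCC(=O)O)c1ccc2c(ccn2Cc2cccc(C)c2)c1` is next. Its change from compound 3 is 3-methylphenyl in place of isopropyl on a saturated chain carbon bound to an aromatic nitrogen. For the measured compounds named here, the two steps that bear on it, 1>3 and 2>3, both show that the isopropyl branch gave a modestly higher number than a straight chain; compound 4 removes that branch but brings in a ring, something no measured compound carries at this place. The expectation is therefore a step of a 4.0-fold lower number from compound 3 to compound 4 (0.60 log units; beyond the scatter) toward a lower number, roughly returning to the region of compound 1 but with wide uncertainty. For compound 4 the estimate in this assay is 40 nM, expected to fall between 10 nM and 160 nM.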

Compound 4, half-maximal inhibitory concentration: 250 nM
Compound 4: the middle estimate sits 6.3-fold (0.80 log units) below what was measured, outside the stated range (above it).
By their numbers in this assay, from the lowest: compounds 2 and 1 (each within the scatter of the next); then compounds 3 and 4 (each within the scatter of the next).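

In this assay, 3-methylphenyl in place of isopropyl on a saturated chain carbon bound to an aromatic nitrogen leaves the two compounds unresolved (a 1.6-fold higher number from compound 3 to compound 4 (0.19 log units; within the scatter)), so bringing in a ring here does not recover the numbers of the straight chains. Measured against those chains, the ring-bearing group gives clear steps in the same direction as the isopropyl branch (a 5.8-fold higher number from compound 1 to compound 4 (0.76 log units; beyond the scatter); an 11-fold higher number from compound 2 to compound 4 (1.04 log units; beyond the scatter)), the second of them large. Across these four compounds, the straight chains of compound 1 and compound 2 therefore hold the lower numbers, the groups of compound 3 and compound 4 hold the higher ones, and no compound goes against this split, but no measurement of any other property accompanies it to account for the result.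

Still open, going by these compounds, is whether an unsubstituted benzyl group at this place would behave like the 3-methylbenzyl group of compound 4 or would come closer to the straight chains. Also open, on these data alone, is whether a longer straight chain than that of compound 2, or a chain ending in an amine or a carboxylic acid, would keep the lower numbers.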